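Replacing a Saturated Ring with a Methoxyphenyl Group

The source may report more compounds than this note shows. Statements on the series, on what has been measured and on what is new or still open speak of the compounds shown alone.

Measured so far:
compound 1, `O=C(O)c1ccccc1-c1ccc(CCc2ncc(CC3CCC3)[nH]2)cc1`: 588 nM
compound 2, `O=C(O)c1ccccc1-c1ccc(CCc2ncc(CC3CCCC3)[nH]2)cc1`: 133 nM

In an in vitro functional assay on cells for agonist activity at Bombesin receptor subtype-3 (Homo sapiens), read by luminescence and calcium flux (a higher number here means that more compound is needed for the effect, a lower number that less compound is needed), compound 2 stands at the lower of the two numbers, a position reached through a 4.4-fold lower number from compound 1 to compound 2 (0.65 log units; beyond the scatter). Compound 3, `COc1cccc(Cc2cnc(CCc3ccc(-c4ccccc4C(=O)O)cc3)[nH]2)c1`, differs from compound 2 by 3-methoxyphenyl in place of cyclopentyl on a saturated chain carbon bound to an aromatic carbon. That measured step is the only one bearing on this place, and it concerns a small change between two saturated rings, whereas here a saturated ring gives way to an aromatic one carrying an oxygen. The direction is therefore uncertain, and the change is expected to stay within a 1.1-fold higher number from compound 2 to compound 3 (0.05 log units; within the scatter) of compound 2. For compound 3 the estimate in this assay is 150 nM, expected between 40 nM and 600 nM.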

Compound 3, half-maximal effective concentration: 4120 nM
For compound 3 the middle estimate is 27-fold (1.44 log units) below the measured one, and the stated range ends below it.
By their numbers in this assay, from the lowest: compound 2; then compound 1; then compound 3.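

In this assay, 3-methoxyphenyl gives a 31-fold higher number from compound 2 to compound 3 (1.49 log units; beyond the scatter) and a 7.0-fold higher number from compound 1 to compound 3 (0.85 log units; beyond the scatter) at this saturated chain carbon, so here it falls behind both cyclobutyl and cyclopentyl. The position is therefore far from indifferent to which ring it carries, a point that the two saturated rings alone could not show. Going by these compounds, whether the loss comes from the aromatic ring or from its methoxy group stays open, and so does how an unsubstituted phenyl or a cyclohexyl ring would compare. No measurement available here accounts for the loss.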